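This account rests on a few compounds, and the source may have more. Where it says the series, first, only, none or still open, it means among the compounds named here.

Compound 1 `CS(=O)(=O)c1ccc(Nc2ncc(F)c(Nc3nc4ccccc4s3)n2)cc1` gives 3170 nM in a functional assay on HeLa cells (Homo sapiens) for antiproliferative activity, read by MTT assay, with a stated time of 48 h (on this read-out lower numbers stand for stronger inhibition and higher numbers for weaker inhibition), the highest of the two numbers on hand. Compound 3 `Cc1cnc(Nc2ccc(S(C)(=O)=O)cc2)nc1Nc1nc2ccccc2s1` gives 460 nM, and the step of a 6.9-fold lower number from compound 1 to compound 3 (0.84 log units; beyond the scatter) is modest. Compound 2 `Cc1cnc(Nc2ccc(C(C)C)cc2)nc1Nc1nc2ccccc2s1` reaches only > 50000 nM in this assay, which is a limit and not a number (the limit of > 50000 nM in this assay, at which 1 of the 3 values shown sits). The step of an at least 100-fold lower number from compound 2 to compound 3 (2.03 log units; beyond the scatter) is large. Compound 4 `Cc1ccc2nc(Nc3nc(Nc4ccc(S(C)(=O)=O)cc4)ncc3F)sc2c1` differs from compound 1 by methyl in place of hydrogen on an aromatic carbon. This change sits at a different place from both measured steps, so neither bears on it directly, and no step beyond the scatter is therefore expected in this assay from compound 1 to compound 4. Compound 4 is estimated at 2500 nM, within a range of 800 nM to 8000 nM. The expected step is a 1.3-fold lower number from compound 1 to compound 4 (0.10 log units; within the scatter).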

Compound 4, half-maximal inhibitory concentration: 17200 nM
Compound 4: middle estimate off by 6.9-fold (0.84 log units), on the low side, outside the stated range (above it).
By their numbers in this assay, from the lowest: compound 3; then compound 1; then compound 4. At a limit, above all of these: compound 2.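

In this assay, methyl in place of hydrogen on the six-membered aromatic ring of carbon only gives a 5.4-fold higher number from compound 1 to compound 4 (0.73 log units; beyond the scatter), so inhibition at this position weakens with the added group. Both earlier steps changed other places; this one shows that the fused part of the core also shapes the read-out, and that a single added carbon is enough to do so. Going by these compounds, whether a chloro group, a methoxy group or an amine on this carbon would act as methyl does remains open. Nothing on hand explains the step.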